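Removing the side chain from compound 2

The source may report more compounds than this note shows. Statements on the series, on what has been measured and on what is new or still open speak of the compounds shown alone.

Compound 1 `Cc1cc(Nc2cc(-c3ccccc3)[nH]n2)n2nc(SCC3CCCCC3)nc2n1`: > 50000 nM, a limit of the assay
Compound 2 `COc1ccc(CSc2nc3nc(C)cc(Nc4cc(-c5ccccc5)[nH]n4)n3n2)cc1`: 8110 nM

For the measured compounds named here, in a functional assay on PC-9 cells (Homo sapiens) for inhibition, read by MTT assay, with a stated time of 72 h (on this read-out lower numbers stand for stronger inhibition and higher numbers for weaker inhibition), compound 2 gives 8110 nM, the only exact value so far. Compound 3 `Cc1cc(Nc2cc(-c3ccccc3)[nH]n2)n2ncnc2n1` differs from it as follows: hydrogen in place of (4-methoxybenzyl)sulfanyl on an aromatic carbon. In words, this is hydrogen in place of (4-methoxybenzyl)sulfanyl on an aromatic carbon. Going by the values given here, only one measured step bears on this, an at least 6.1-fold lower number from compound 1 to compound 2 (0.78 log units; beyond the scatter), which lies beyond the scatter and changed the end group of this same sulfur-linked side chain. Compound 3 loses that side chain entirely, so weaker inhibition is expected, with an estimated 4.9-fold higher number from compound 2 to compound 3 (0.69 log units; beyond the scatter). For compound 3 the expected value is 40000 nM, within an estimated range of 12000 nM to 120000 nM.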

Compound 3, half-maximal inhibitory concentration: > 50000 nM
Compound 3 gave a limit, no number; the forecaster's own chance of this, stated with the estimate: 55%; middle value at least 1.2-fold (0.09 log units) from the limit.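

Earlier, only the end of the sulfur-linked side chain had changed; replacing the whole (4-methoxybenzyl)sulfanyl group with hydrogen gives an at least 6.1-fold higher number from compound 2 to compound 3 (0.78 log units; beyond the scatter), so a bare aromatic carbon at this position does not retain the inhibition seen with compound 2. The value of compound 3 is a limit, not a number. The step from compound 1 to compound 3 cannot be read, because both values sit at the same limit: the limit of > 50000 nM in this assay, at which 2 of the 3 values shown sit.

As far as these compounds go, it remains open whether the sulfur or the 4-methoxyphenyl end carries the effect. A small methylsulfanyl group or an amine on this carbon could help separate the two.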